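Methyl on the Thiadiazole: Expected Sodium Channel Inhibition

The compounds below may be only part of what the source reports. "The series", "measured", "known", "first", "only" and "open" are said of these compounds alone.

Measured so far:
compound 1: `Cn1nccc1[C@H]1CCC[C@@H]1Oc1cc(F)c(S(=O)(=O)Nc2nccs2)cc1F` gives 13000 nM
compound 2: `Cn1nccc1[C@H]1CCC[C@@H]1Oc1cc(F)c(S(=O)(=O)Nc2ncns2)cc1F` gives 26000 nM

Both compounds were tested in an ADME assay on HEK293-A cells for inhibition of sodium channel protein type 1 subunit alpha/beta-1/beta-2 (Homo sapiens), read by patch clamp; a lower number here means a stronger inhibitor, a higher number a weaker inhibitor. They share one core and differ only in the five-membered ring attached to the sulfonamide nitrogen. Among the measured compounds shown here, the single measured step, a 2.0-fold higher number from compound 1 to compound 2 (0.30 log units; within the scatter), exchanges one such ring for another and stays within the scatter. For the measured compounds named here, of the two numbers, the one for compound 2 is the larger, but its gap to compound 1 lies within the scatter, so the two compounds cannot be told apart on these data.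

Compound 3, `Cc1nsc(NS(=O)(=O)c2cc(F)c(O[C@H]3CCC[C@@H]3c3ccnn3C)cc2F)n1`, differs from compound 2 by methyl in place of hydrogen on an aromatic carbon. Going by the values given here, no measured step involves adding a methyl group, so there is nothing that directly bears on this change; the only step available concerns the ring itself and produced no shift beyond the scatter. Compound 3 is therefore expected to sit close to compound 2, with the expected step of no change at the digits printed from compound 2 to compound 3 (within the scatter) being none beyond the scatter. Compound 3 is estimated at 26000 nM, with a range from 10000 nM to 65000 nM.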

Compound 3, half-maximal inhibitory concentration in the sodium channel protein type 1 subunit alpha/beta-1/beta-2 assay: > 100000 nM
Compound 3 was reported as a limit; the forecaster's own chance of this, stated with the estimate: 20%; middle value at least 3.8-fold (0.58 log units) from the limit.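

In the sodium channel protein type 1 subunit alpha/beta-1/beta-2 assay compound 3 gives > 100000 nM, which is a limit of the assay and not a number. The methyl in place of hydrogen, on the aromatic carbon between two ring nitrogen atoms, produces an at least 3.8-fold higher number from compound 2 to compound 3 (0.58 log units; beyond the scatter) and so gives the first shift beyond the scatter, something the earlier exchange of one ring for another (a 2.0-fold higher number from compound 1 to compound 2 (0.30 log units; within the scatter)) did not do. The full change at the sulfonamide nitrogen, with 3-methyl-1,2,4-thiadiazol-5-yl in place of 1,3-thiazol-2-yl, amounts to an at least 7.6-fold higher number from compound 1 to compound 3 (0.88 log units; beyond the scatter) and shows that this one added carbon weakens inhibition more clearly than the ring exchange alone.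

From the compounds shown here alone, the true size of the loss stays open with only a limit for compound 3, as does whether the loss belongs to methyl alone or would recur with another group on the same carbon, such as an amine or a methoxy group. In a physicochemical assay for solubility, read by HPLC, measured as thermodynamic solubility, with a stated time of 4 h, at pH 6.8 (a higher number here means a more soluble compound, a lower number a less soluble compound), compound 2 gives > 1900000 nM, which is a limit of the assay and not a number. In the physicochemical assay compound 3 gives 1800000 nM. Going by these compounds, in the physicochemical assay the comparison gives only an at least 1.0-fold lower number from compound 2 to compound 3 (0.02 log units; that floor lies within the scatter) as a floor, so it also remains open whether the methyl changes solubility at all.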